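The source may report more compounds than this note shows. Statements on the series, on what has been measured and on what is new or still open speak of the compounds shown alone.

Measured so far:
- compound 1, `Cc1cccc(Nc2nc(-c3ccncc3-c3ccc(S(C)(=O)=O)cc3)cs2)c1`, in a functional assay on RCC4 cells (Homo sapiens) for inhibition, read by XTT assay, with a stated time of 4 days (a lower number here means a stronger inhibitor, a higher number a weaker inhibitor), compound 1 gives 1600 nM; 1620 nM (2 entries)
- compound 2, `Cc1cccc(Nc2nc(-c3ccncc3CCCO)cs2)c1`, compound 2 gives 6920 nM
- compound 3, `Cc1cccc(Nc2nc(-c3ccncc3)c(CN(C)C)s2)c1`, compound 3 gives 16200 nM

All three share the same core and differ in what is attached to it. Among the two compounds that have a single number in this assay, compound 2 stands lowest; the nearest is compound 3, and the gap between them is beyond the usual scatter. Compound 1 has two entries, shown in the several entries of compound 1 in this assay, 1600 nM; 1620 nM (2 entries), both lower than compound 2.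

The compound yet to be measured is compound 4, `CCc1cnccc1-c1csc(Nc2cccc(C)c2)n1`. Compared with compound 2 the change is hydrogen in place of hydroxymethyl on a saturated chain carbon, two bonds along the chain from an aromatic carbon. In plain words, the 3-hydroxypropyl chain of compound 2 becomes an ethyl chain in compound 4.

Among the measured compounds shown here, no pair of measured compounds differs in exactly this way, so the size of the step has to be guessed. The expectation is a step of modest size in this assay, if any beyond the scatter, with a slight lean toward a higher number rather than a lower one. The expected step from compound 2 to compound 4 is a 1.2-fold higher number from compound 2 to compound 4 (0.06 log units; within the scatter). For compound 4 the estimated value in this assay is 8000 nM, with a likely range from 3000 nM to 25000 nM.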

Compound 4, half-maximal inhibitory concentration: 6310 nM
Estimate against measurement, compound 4: 1.3-fold (0.10 log units) above; measured number inside the range.
By their numbers in this assay, from the lowest: compounds 4 and 2 (each within the scatter of the next); then compound 3.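

In this assay, among the compounds shown here, the change from the 3-hydroxypropyl chain to the ethyl chain gives a 1.1-fold lower number from compound 2 to compound 4 (0.04 log units; within the scatter) and thus offers the first direct reading at this place on the chain. The hydroxymethyl end, with its hydrogen-bond donor and hydrogen-bond acceptor, can be replaced by hydrogen with no change that stands out from the usual spread of repeated measurements, so the two chains cannot be told apart in this read-out. Nothing measured here explains why the number stays put.

For the compounds shown here, this single step covers only one swap, so it remains open whether an amine or a carboxylic acid at the end of the chain would shift the number beyond the scatter. The effect of chain length alone is open too, since a methyl group or a longer chain made only of carbon could give a different reading from either the ethyl or the 3-hydroxypropyl chain.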